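The source may hold more compounds than are shown below. What is called first, only, known or untested is meant among the compounds shown, and "the series" means these compounds.

Measured compounds:
- compound 1, `COc1ccc2occ(CSC(=S)N3CCCCC3)c(=O)c2c1`: 4700 nM
- compound 2, `O=c1cc(CSC(=S)N2CCCCC2)oc2cc(Cl)ccc12`: 13800 nM
- compound 3, `CCN(CC)C(=S)SCc1cc(=O)c2ccc(Cl)cc2o1`: 8800 nM

All three were tested in a functional assay on LM7 cells (Homo sapiens) for antiproliferative activity, read by MTT assay, with a stated time of 72 h; on this read-out higher numbers stand for weaker inhibition and lower numbers for stronger inhibition. Compound 1 and compound 3 cannot be told apart, as their gap lies within the scatter; compound 2 stands beyond the scatter, with the higher number. Compound 1 shares its core with the new compound 4, `COc1ccc2occ(CSC(=S)N3CCCC3)c(=O)c2c1`, and the two differ in one place only: pyrrolidin-1-yl in place of piperidin-1-yl on a thiocarbonyl carbon.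

Going by the values given here, one measured step bears on this kind of change, where the group on the thiocarbonyl carbon is swapped while the rest of the molecule is kept: a 1.6-fold lower number from compound 2 to compound 3 (0.20 log units; within the scatter). That swap did not move the number beyond the scatter, so a change of the ring size on the same thiocarbonyl carbon is expected to leave this assay largely unchanged as well, with no step beyond the scatter in either direction. The step expected is therefore no change at the digits printed from compound 1 to compound 4 (within the scatter). On this basis compound 4 is estimated to give 4700 nM, within a range from 2000 nM to 11000 nM.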

Compound 4, half-maximal inhibitory concentration: 6000 nM
For compound 4 the middle estimate is 1.3-fold (0.11 log units) below the measured one; measured number inside the range.
By their numbers in this assay, from the lowest: compounds 1, 4, 3 and 2 (each within the scatter of the next, the first and the last beyond it).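

In this assay, pyrrolidin-1-yl in place of piperidin-1-yl gives a 1.3-fold higher number from compound 1 to compound 4 (0.11 log units; within the scatter). The earlier step at this thiocarbonyl carbon exchanged a ring for open diethylamino on a different core, whereas this one compares two rings on the core of compound 1, and here too the difference stays within the scatter, so this assay does not separate the five-membered ring from the six-membered one on this core. Nothing measured on these compounds explains this result.

The compounds shown leave open whether the number would hold with a larger ring such as azepan-1-yl, or with a ring holding a second hetero atom such as morpholin-4-yl or piperazin-1-yl. They also leave open whether a small open group such as dimethylamino would behave like diethylamino on the core of compound 1.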